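This account rests on a few compounds, and the source may have more. Where it says the series, first, only, none or still open, it means among the compounds named here.

Compound 1 `CCOC(=O)c1ccc(NC(=S)NCc2ccncc2)cc1` gives 9770 nM in an assay on isolated protein for activation of Nicotinamide phosphoribosyltransferase (Homo sapiens); a lower number here means that less compound is needed, a higher number that more compound is needed for the effect.
Compound 2 `CN(C1CCCC1)S(=O)(=O)c1ccc(NC(=O)NCc2ccncc2)cc1` gives 123 nM.
Compound 3 `CCOC(=O)c1ccc(NC(=O)OCc2ccncc2)cc1` gives 10800 nM.

Among the measured compounds shown here, of the three numbers so far, compound 2 stands lowest in this assay; compound 1 lies far higher and compound 3 higher still, both gaps beyond the scatter. The two higher compounds carry an ethyl ester where compound 2 carries a sulfonyl group, and their linkers differ too, so neither offers a one-place comparison.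

The unmeasured compound 4 `O=C(NCc1ccncc1)Nc1ccc(S(=O)(=O)c2ccccc2)cc1` keeps the urea and the pyridylmethyl arm of compound 2 and changes a single group: phenyl in place of cyclopentyl(methyl)amino on a sulfonyl sulfur. For the measured compounds named here, no step between measured compounds touches this position, so its size has no direct guide here. The sulfonyl group itself remains in place. The number for compound 4 is expected to move only a little from that of compound 2, if anything to a somewhat higher value. The expected step is a 2.0-fold higher number from compound 2 to compound 4 (0.31 log units; beyond the scatter), which may well stay within the scatter. The estimate for compound 4 in this assay is 250 nM, with a range from 60 nM to 1500 nM.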

Compound 4, half-maximal effective concentration: 85 nM
The estimate for compound 4 lay 2.9-fold (0.47 log units) above the measured number, and the stated range covers the measured number.
By their numbers in this assay, from the lowest: compounds 4 and 2 (each within the scatter of the next); then compounds 1 and 3 (each within the scatter of the next).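

In this assay there is now a one-place comparison at this position: phenyl in place of cyclopentyl(methyl)amino on a sulfonyl sulfur gives a 1.4-fold lower number from compound 2 to compound 4 (0.16 log units; within the scatter) and so no change that can be told from scatter. In this pair, neither the nitrogen nor the five-membered non-aromatic ring of the leaving group is needed for a number of this order, since a six-membered aromatic ring of carbon only serves as well. Nothing measured here bears on why the two groups give such similar numbers.

Going by these compounds, whether this holds for other groups on the sulfonyl sulfur, such as a morpholine ring, a simple methyl or a longer alkyl chain, stays open. Compound 1 and compound 3 differ from compound 2 in more than one place, so the separate parts played by the ethyl ester, the thiourea and the carbamate cannot be read.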